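Replacing a 2-methylphenyl with a 4-cyanobenzyl substituent

This account rests on a few compounds, and the source may have more. Where it says the series, first, only, none or still open, it means among the compounds named here.

Of the compounds shown here, three built on one shared core have been measured in a functional assay on PC-3 cells (Homo sapiens) for inhibition, read by MTT assay, with a stated time of 72 h; a higher number here means a weaker inhibitor, a lower number a stronger inhibitor. Compound 1 `Cc1ccc(-n2cc(CNC(=O)c3cccc4c3cnn4C(C)C)nn2)c(C)c1` gives 10600 nM, compound 2 `Cc1cccc(-n2cc(CNC(=O)c3cccc4c3cnn4C(C)C)nn2)c1` gives 32300 nM, and compound 3 `Cc1ccccc1-n1cc(CNC(=O)c2cccc3c2cnn3C(C)C)nn1` gives 19200 nM. The number for compound 3 is the second highest of the three, though a 1.7-fold lower number from compound 2 to compound 3 (0.23 log units; within the scatter) and a 1.8-fold higher number from compound 1 to compound 3 (0.26 log units; within the scatter) both lie within the scatter, while a 3.0-fold higher number from compound 1 to compound 2 (0.48 log units; beyond the scatter) is a modest step beyond it. Compound 4 `CC(C)n1ncc2c(C(=O)NCc3cn(Cc4ccc(C#N)cc4)nn3)cccc21` differs from compound 3 by 4-cyanobenzyl in place of 2-methylphenyl on an aromatic nitrogen. Going by the values given here, no measured step involves such an exchange; all three merely shift methyl groups and stay small. Compound 4 is therefore expected to land near the number of its parent in this assay, with a step of a 1.3-fold lower number from compound 3 to compound 4 (0.11 log units; within the scatter) and an estimated value of 15000 nM, ranging from 4000 nM to 55000 nM.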

Compound 4, half-maximal inhibitory concentration: 18200 nM
For compound 4 the middle estimate is 1.2-fold (0.08 log units) below the measured one; the measured number falls inside the stated range.
By their numbers in this assay, from the lowest: compounds 1, 4, 3 and 2 (each within the scatter of the next, the first and the last beyond it).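

In this assay the move from an aryl group directly on the aromatic nitrogen to 4-cyanobenzyl, with its nitrile, gives a 1.1-fold lower number from compound 3 to compound 4 (0.02 log units; within the scatter) and leaves the number level with the other two compounds as well, with a 1.8-fold lower number from compound 2 to compound 4 (0.25 log units; within the scatter) and a 1.7-fold higher number from compound 1 to compound 4 (0.23 log units; within the scatter) as the remaining steps. This position therefore accepts a larger group carrying a hydrogen-bond acceptor with no step beyond the scatter. Nothing available explains this result. On these data alone, whether an amine or a carboxylic acid in place of the nitrile, or a longer chain in place of the benzyl group, would move the number beyond the scatter remains open.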